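Aryl swap on the acrylohydrazide arm of the coumarin series

A few compounds are considered here, and "the series" means these few. Any claim that something is new, unique, unknown or untested is made for them only; others in the source may bear on it.

Three members of the series have been measured in a functional assay on NRK-49F cells (Rattus norvegicus) for cytotoxicity, read by MTT assay, with a stated time of 24 h; on this read-out higher numbers stand for weaker inhibition and lower numbers for stronger inhibition. Compound 1 `C/C(=N\NC(=O)/C(C#N)=C/c1ccccc1)c1c(O)c2ccc(O)cc2oc1=O` gives 55500 nM. Compound 2 `COc1cc(/C=C(\C#N)C(=O)N/N=C(\C)c2c(O)c3ccc(O)cc3oc2=O)ccc1O` gives 55400 nM. Compound 3 `COc1ccc(/C=C(\C#N)C(=O)N/N=C(\C)c2c(O)c3ccc(O)cc3oc2=O)cc1` gives 96100 nM. Compound 2 holds the lowest number of the three, but its nearest neighbour is compound 1, a 1.0-fold lower number from compound 1 to compound 2 (0.00 log units; within the scatter), and its furthest is compound 3, a 1.7-fold higher number from compound 2 to compound 3 (0.24 log units; within the scatter); neither gap exceeds the scatter, so no ordering among the three can be claimed.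

Compound 4 `C/C(=N\NC(=O)/C(C#N)=C/c1ccccc1[N+](=O)[O-])c1c(O)c2ccc(O)cc2oc1=O` is not yet measured. Relative to compound 2 the change is 2-nitrophenyl in place of 4-hydroxy-3-methoxyphenyl on a double-bonded chain carbon bound to a double-bonded chain carbon.

For the measured compounds named here, the steps that bear on this change are the two earlier swaps of the aryl group on the same chain carbon: a 1.0-fold lower number from compound 1 to compound 2 (0.00 log units; within the scatter) and a 1.7-fold higher number from compound 2 to compound 3 (0.24 log units; within the scatter), both within the scatter. Across phenyl, 4-hydroxy-3-methoxyphenyl and 4-methoxyphenyl the read-out in this assay has stayed flat, so no step beyond the scatter is expected in either direction for the 2-nitrophenyl analogue. The expected step is a 1.1-fold higher number from compound 2 to compound 4 (0.03 log units; within the scatter). Compound 4 is accordingly estimated at 60000 nM, with a range from 30000 nM to 120000 nM.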

Compound 4, half-maximal inhibitory concentration: 68600 nM
Estimate against measurement, compound 4: 1.1-fold (0.06 log units) below, within the range that was stated.
By their numbers in this assay, from the lowest: compounds 2, 1, 4 and 3 (each within the scatter of the next).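

Nitro on the aromatic ring is the first nitrogen-bearing substituent on the aryl group at this chain carbon, and in this assay it gives no step beyond the scatter: a 1.2-fold higher number from compound 1 to compound 4 (0.09 log units; within the scatter). The comparisons with the two methoxy-bearing aryl groups read the same way, with a 1.2-fold higher number from compound 2 to compound 4 (0.09 log units; within the scatter) and a 1.4-fold lower number from compound 3 to compound 4 (0.15 log units; within the scatter), so replacing 4-hydroxy-3-methoxyphenyl, which carries a hydrogen-bond donor, with 2-nitrophenyl, which carries none, also leaves the read-out within the scatter, and all four aryl groups now lie within the scatter of one another. Nothing measured alongside these numbers accounts for this flat read-out, which remains an observation on these four compounds only.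

Still open, as far as these compounds go, is whether any group on this double-bonded chain carbon can move the number beyond the scatter, for instance an aryl ring carrying a dimethylamino group or a carboxylic acid, or a saturated cyclohexyl ring in place of the aromatic one. The compounds shown also leave open whether the read-out responds to changes outside the aryl group, such as replacing the nitrile with a carboxamide, since all four keep that group and the shared core unchanged.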